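Methyl Carbamate in Place of the Methylaminoacetamide

The source may hold more compounds than are shown below. What is called first, only, known or untested is meant among the compounds shown, and "the series" means these compounds.

Within the data shown here, in an assay on isolated protein for displacement of a labelled ligand from 5-hydroxytryptamine receptor 6 (Homo sapiens) (a lower number here means a stronger inhibitor, a higher number a weaker inhibitor), compound 2 `CNCC(=O)NC[C@@H]1CCCc2cc(S(=O)(=O)c3cccc(F)c3)ccc21` gives 0.159 nM, the lowest of the two numbers so far; compound 1 `O=S(=O)(O)CCCNC[C@@H]1CCCc2cc(S(=O)(=O)c3cccc(F)c3)ccc21` gives 1.26 nM. Among the measured compounds shown here, the one measured step, a 7.9-fold lower number from compound 1 to compound 2 (0.90 log units; beyond the scatter), shows that changing what sits on the amine nitrogen shifts the read-out by a modest amount. Compound 3 `COC(=O)NC[C@@H]1CCCc2cc(S(=O)(=O)c3cccc(F)c3)ccc21` carries methoxy in place of (methylamino)methyl on a carbonyl carbon. For the measured compounds named here, no measured step covers this exact change, so that single step only sets the likely scale. The expected step is a 3.1-fold higher number from compound 2 to compound 3 (0.50 log units; beyond the scatter), a modest weakening. Compound 3 is estimated to give 0.5 nM, within 0.15 nM to 2 nM.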

Compound 3, inhibition constant: 1.59 nM
Compound 3: the middle estimate sits 3.2-fold (0.50 log units) below what was measured, within the range that was stated.
By their numbers in this assay, from the lowest: compound 2; then compounds 1 and 3 (each within the scatter of the next).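

In this assay, methoxy in place of (methylamino)methyl on the carbonyl carbon gives a 10-fold higher number from compound 2 to compound 3 (1.00 log units; beyond the scatter), so this position responds to the change and the low number of compound 2 does not carry over to the carbamate. The methoxycarbonyl group does not move the read-out beyond the 3-sulfopropyl group on the amine nitrogen, with a 1.3-fold higher number from compound 1 to compound 3 (0.10 log units; within the scatter). Nothing measured here gives a reason for either step.

From the compounds shown here alone, whether an aminomethyl or an ethoxy group on the same carbonyl carbon would read like compound 2 or like compound 3 stays open.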